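This account rests on a few compounds, and the source may have more. Where it says the series, first, only, none or still open, it means among the compounds named here.

For the measured compounds named here, compound 1 `CC(C)C[C@@H]1NC(=O)[C@H](CS)NC1=O` sits at the top of the two numbers so far in a functional assay, tested at 2.5 mM (on this read-out lower numbers stand for less inhibition and higher numbers for more inhibition at the one concentration tested (going by the name of the read-out)), where compound 1 gives 83.3%. Compound 2 `CC(C)C[C@@H]1NC(=O)[C@H](CCC(=O)O)NC1=O` shares the same core, and in this assay compound 2 gives 0%. Going by the values given here, the single measured step, a number 83.3 percentage points lower from compound 1 to compound 2 (beyond the scatter), shows that the whole inhibition disappears once the sulfanyl group is gone. Compound 3 `CSCC[C@@H]1NC(=O)[C@H](CC(C)C)NC1=O` has not yet been measured. Its change against compound 1 is (methylsulfanyl)methyl in place of sulfanyl on a saturated chain carbon bound to a saturated ring carbon. Among the compounds with values here, one measured step bears on this change, because a number 83.3 percentage points lower from compound 1 to compound 2 (beyond the scatter) likewise removed the sulfanyl group, although a different group entered there. Within the data shown here, with only that one step available, a large drop in this assay seems the likeliest outcome for compound 3, with some uncertainty since the entering group is not the same. Compound 3 is therefore expected to give about 20%, somewhere between 0% and 55%. That corresponds to an expected step of a number 63.3 percentage points lower from compound 1 to compound 3 (beyond the scatter).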

Compound 3, a percentage reported as inhibition, at one concentration (the size of the read-out at that concentration, not a potency): 0%
The estimate for compound 3 lay 20 percentage points above the measured number, within the range that was stated.
By their numbers in this assay, from the lowest: compounds 2 and 3 (each within the scatter of the next); then compound 1.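

Sulfur in the entering group does not preserve the inhibition: with (methylsulfanyl)methyl in place of sulfanyl, this assay shows a number 83.3 percentage points lower from compound 1 to compound 3 (beyond the scatter) even though the new group still holds a sulfur atom. Unlike sulfanyl, that group counts no hydrogen-bond donor, but the data do not show whether this difference matters. Swapping carboxy for methylsulfanyl further out on the chain gives no change at the digits printed from compound 2 to compound 3 (within the scatter) and so, at this position, the two replacements cannot be told apart on this read-out. No supporting data give a reason for these results.

Open, from the compounds shown here alone, is whether a sulfanyl group survives being moved outward on a longer chain, as in 2-sulfanylethyl. Also open, going by these compounds, is whether a hydroxymethyl or aminomethyl group, with oxygen or nitrogen in place of the sulfur, could restore any inhibition.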